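Cyclohexyl in Place of Neopentyl on an Aromatic Nitrogen

A few compounds are considered here, and "the series" means these few. Any claim that something is new, unique, unknown or untested is made for them only; others in the source may bear on it.

Measured compounds:
compound 1, `CC(C)c1onc(-c2c(Cl)cccc2Cl)c1COc1ccc(-c2nc3ccc(C(=O)O)cc3n2CC(C)(C)C)cc1`, 861 nM in an assay on HEK-293T cells for antagonist activity at vitamin D3 receptor (Homo sapiens), read by a luciferase reporter, with a stated time of 24 h; on this read-out lower numbers stand for stronger inhibition and higher numbers for weaker inhibition
compound 2, `CC(C)c1onc(-c2c(Cl)cccc2Cl)c1COc1ccc(-c2nc3ccc(C(=O)O)cc3n2C2CCC2)cc1`, 1100 nM in this assay

Among the measured compounds shown here, compound 1 stands with the lower of the two numbers, but its only neighbour, compound 2, lies within the scatter of it: the single measured step, a 1.3-fold higher number from compound 1 to compound 2 (0.11 log units; within the scatter), is too small to count as a change. Compound 3, `CC(C)c1onc(-c2c(Cl)cccc2Cl)c1COc1ccc(-c2nc3ccc(C(=O)O)cc3n2C2CCCCC2)cc1`, differs from compound 1 by cyclohexyl in place of neopentyl on an aromatic nitrogen. The step from compound 1 to compound 2 bears directly on this, since it also swapped the neopentyl on that aromatic nitrogen for a ring, cyclobutyl, and the number barely moved. Cyclohexyl is a larger ring than cyclobutyl, and no measured pair tells what further growth on this nitrogen does, so no step beyond the scatter is expected in this assay. Compound 3 is therefore estimated at 1000 nM, between 450 nM and 2300 nM, which means an expected step of a 1.2-fold higher number from compound 1 to compound 3 (0.06 log units; within the scatter).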

Compound 3, half-maximal inhibitory concentration: 1450 nM
The estimate for compound 3 lay 1.5-fold (0.16 log units) below the measured number, within the range that was stated.
By their numbers in this assay, from the lowest: compounds 1, 2 and 3 (each within the scatter of the next).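

Cyclohexyl is a second ring that can replace neopentyl on this aromatic nitrogen without a change that can be read in this assay: the swap gives a 1.7-fold higher number from compound 1 to compound 3 (0.23 log units; within the scatter) and so stays inside the scatter, as the cyclobutyl swap did. Going from the four-membered ring to the six-membered one gives a 1.3-fold higher number from compound 2 to compound 3 (0.12 log units; within the scatter) and is also inside the scatter, so these three compounds show no effect of ring size or of ring against open chain at this position. Nothing available on these compounds offers an explanation for the result.

The compounds shown leave open whether a substituent on this nitrogen bearing an amine or a hydroxyl group, or a longer chain, would move the number beyond the scatter. They also leave open whether a phenyl ring there would do so.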